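The source may report more compounds than this note shows. Statements on the series, on what has been measured and on what is new or still open speak of the compounds shown alone.

Compound 3 `CCCc1ccc(-c2ccc(N(C[C@@H](N)[C@@H](C)CC)C(=O)[C@@H]3C[C@H]3c3ccccc3)cc2)cc1` sits second highest of the three numbers in hand. In a functional assay for agonist activity at G protein-coupled receptor 88 (Homo sapiens), read by HTRF and cAMP accumulation (a higher number here means that more compound is needed for the effect, a lower number that less compound is needed), compound 3 gives 61 nM. Its nearest neighbour is compound 1 `O=C([C@@H]1C[C@H]1c1ccccc1)N(CC1CCCNC1)c1ccc(-c2ccccc2)cc1`, which in this assay gives 10 nM, a gap that lies beyond the usual scatter. Furthest away is compound 2 `CC(C)C[C@H](N)CN(C(=O)[C@@H]1C[C@H]1c1ccccc1)c1ccc(-c2cccs2)cc1`, which in this assay gives 1500 nM, again beyond the scatter. Compound 4 `CC[C@H](C)[C@H](N)CN(C(=O)[C@@H]1C[C@H]1c1ccccc1)c1ccc(-c2ccc(COC(C)(C)C)cc2)cc1` differs from compound 3 in one place: tert-butoxy in place of ethyl on a saturated chain carbon bound to an aromatic carbon. Taken one bond further out, the change reads propyl to (tert-butoxy)methyl, so the 4-propylphenyl end of compound 3 becomes 4-((tert-butoxy)methyl)phenyl. Among the compounds with values here, no measured pair isolates this change, so its effect cannot be read from the set. Compound 3 and compound 1 show that the aryl tail tolerates variation within a range of moderate size, while compound 2 shows that other changes at this end can cost far more. The expected step from compound 3 to compound 4 is a 1.8-fold higher number from compound 3 to compound 4 (0.26 log units; within the scatter), a modest move toward a higher number. Compound 4 is therefore estimated at 110 nM, with a range from 30 nM to 400 nM.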

Compound 4, half-maximal effective concentration: 280 nM
Estimate against measurement, compound 4: 2.5-fold (0.41 log units) below, and the stated range covers the measured number.
By their numbers in this assay, from the lowest: compound 1; then compound 3; then compound 4; then compound 2.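

In this assay, within the data shown here, tert-butoxy in place of ethyl on a saturated chain carbon bound to an aromatic carbon gives a 4.6-fold higher number from compound 3 to compound 4 (0.66 log units; beyond the scatter), the first step in the set that isolates a single change at this end of the molecule. It shows that 4-propylphenyl cannot be exchanged for 4-((tert-butoxy)methyl)phenyl without cost, though the cost is modest for a group with more heavy atoms and a hydrogen-bond acceptor that ethyl lacks. Nothing in hand explains this shift.

The compounds shown leave open whether the cost follows from the ether oxygen or from the branched carbons of the tert-butyl group, a question that a pentyl chain in place of propyl would help to separate. On these data alone, whether the smaller methoxymethyl group would keep the number of compound 3 also remains open.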